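A few compounds are considered here, and "the series" means these few. Any claim that something is new, unique, unknown or untested is made for them only; others in the source may bear on it.

Measured so far in a physicochemical assay for solubility, read by HPLC, measured as kinetic solubility, at pH 7; a lower number here means a less soluble compound, a higher number a more soluble compound (three compounds):
compound 1 `FC(F)(F)c1c(CN2CCC(c3ccccc3)CC2)ccn2c(CC3CC3)nnc12` gives 3000 nM
compound 2 `Fc1ccccc1C1CCN(Cc2ccn3c(CC4CC4)nnc3c2C(F)(F)F)CC1` gives 2000 nM
compound 3 `Fc1ccc(OC2CCN(Cc3ccn4c(CC5CC5)nnc4c3C(F)(F)F)CC2)c(F)c1` gives 7000 nM

Compound 3 holds the highest of the three numbers. Compound 4 `Fc1ccc(COC2CCN(Cc3ccn4c(CC5CC5)nnc4c3C(F)(F)F)CC2)c(F)c1` carries 2,4-difluorobenzyl in place of 2,4-difluorophenyl on an oxygen on a saturated carbon. Going by the values given here, no measured step makes this change directly. The closest evidence is the exchange that introduced 2,4-difluorophenoxy on the saturated ring carbon (a 2.3-fold higher number from compound 1 to compound 3 (0.37 log units; beyond the scatter)) and (a 3.5-fold higher number from compound 2 to compound 3 (0.54 log units; beyond the scatter)). Both are modest. The fluoro exchange (a 1.5-fold lower number from compound 1 to compound 2 (0.18 log units; within the scatter)) says little here. With only these steps to go on, a step of modest size at most is expected in this assay and its direction is weakly defined. A slight fall is favoured, since compound 3 at 7000 nM sits at the top of a narrow set. The expected step is a 1.8-fold lower number from compound 3 to compound 4 (0.24 log units; within the scatter) on this estimate. For compound 4 the estimated value is 4000 nM (expected range 1500 nM to 10000 nM).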

Compound 4, solubility: 3000 nM
The estimate for compound 4 lay 1.3-fold (0.12 log units) above the measured number; the measured number falls inside the stated range.
By their numbers in this assay, from the lowest: compounds 2, 1 and 4 (each within the scatter of the next); then compound 3.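

In the series, 2,4-difluorobenzyl in place of 2,4-difluorophenyl on an oxygen on a saturated carbon reads in this assay as a step beyond the scatter (a 2.3-fold lower number from compound 3 to compound 4 (0.37 log units; beyond the scatter)), so the higher number of the phenoxy compound does not carry over to the (2,4-difluorobenzyl)oxy group. Against the two compounds without the oxygen, the new group stays within the scatter (no change at the digits printed from compound 1 to compound 4 (within the scatter); a 1.5-fold higher number from compound 2 to compound 4 (0.18 log units; within the scatter)), which leaves compound 3 alone at the top of the four. Nothing available gives a reason for the step.

Still open, going by these compounds, is whether the number of compound 3 holds with other groups on that oxygen, such as a pyridyl ring or a plain butyl chain. A longer chain, such as 2-phenylethyl, would show whether the trend continues past the benzyl group.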